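The source may report more compounds than this note shows. Statements on the series, on what has been measured and on what is new or still open speak of the compounds shown alone.

Measured compounds in an ADME assay on HEp-2 cells (Homo sapiens) for cytotoxicity, read by MTT assay, with a stated time of 3 days; a higher number here means that more compound is tolerated, a lower number that less compound is tolerated:
- compound 1 `CC[C@@H](CCn1cncn1)c1ccc(Cl)cc1` gives 55.1 ug/mL
- compound 2 `CCC[C@@H](CCn1cncn1)c1ccc(F)cc1` gives 55.3 ug/mL

Compound 2 stands level with compound 1 in this assay: the two numbers are within the scatter of each other, so neither can be told apart from the other, and the two compounds, differing in both the chain and the halogen, show the same tolerated concentration. Among the measured compounds shown here, no step between measured compounds that differ in one place is available.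

Compound 3 `CCC[C@@H](CCn1cncn1)c1ccc(Cl)cc1` is not yet measured. It differs from compound 2 in one place: chloro in place of fluoro on an aromatic carbon. The same exchange of halogen, combined with a change of chain, separates compound 1 from compound 2, and in this assay those two give numbers that coincide. On that basis no step beyond the scatter is expected in this assay from compound 2 to compound 3, in either direction.

For compound 3 the expected value in this assay is 55 ug/mL, with a range of 30 ug/mL to 100 ug/mL, the expected step being a 1.0-fold lower number from compound 2 to compound 3 (0.00 log units; within the scatter).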

Compound 3, half-maximal cytotoxic concentration: 36.6 ug/mL
For compound 3 the middle estimate is 1.5-fold (0.18 log units) above the measured one; the measured number falls inside the stated range.
By their numbers in this assay, from the lowest: compounds 3, 1 and 2 (each within the scatter of the next).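

In this assay the exchange of halogen can now be read alone: chloro in place of fluoro on an aromatic carbon, para to a large group, gives a 1.5-fold lower number from compound 2 to compound 3 (0.18 log units; within the scatter) and so leaves these two halogens indistinguishable at this position. The chain change can also be read alone: methyl in place of hydrogen on a saturated chain carbon, three bonds along the chain from an aromatic carbon, gives a 1.5-fold lower number from compound 1 to compound 3 (0.18 log units; within the scatter) and likewise stays inside the scatter, whereas the earlier pair differed in both places at once and could not separate the two changes. Nothing measured bears on what lies behind these numbers.

The compounds shown leave open whether a group other than fluoro or chloro on this aromatic carbon, such as an amine or a carboxylic acid, or a longer chain would give a step beyond the scatter in this assay and thereby show that either place matters for the tolerated concentration. With all three numbers within the scatter of their neighbours, the series as shown does not yet identify any structural feature that sets this concentration.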